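From Hexyl to Pentyloxy in Compound 2

The source may hold more compounds than are shown below. What is called first, only, known or untested is meant among the compounds shown, and "the series" means these compounds.

Values in a physicochemical assay for solubility, read by HPLC, at pH 7.4 (a lower number here means a less soluble compound, a higher number a more soluble compound), so far
- compound 1 `CCCCCCCc1cc(=O)c2cc(C(F)(F)F)ccc2[nH]1` gives < 5000 nM as a limit
- compound 2 `CCCCCCCc1cc(=O)c2cc([N+](=O)[O-])ccc2[nH]1` gives < 5000 nM as a limit
- compound 3 `CCCCCCc1cc(=O)c2cc(C(F)(F)F)ccc2n1C` gives 15000 nM as a number

Compound 2 stands at a limit, not at a number, as the limit of < 5000 nM in this assay, at which 2 of the 3 values shown sit, shows. Compound 4 `CCCCCOCc1cc(=O)c2cc([N+](=O)[O-])ccc2[nH]1` differs from compound 2 by pentyloxy in place of hexyl on a saturated chain carbon bound to an aromatic carbon and so carries pentyloxy in place of hexyl. Within the data shown here, the one measured step is a step that the two limits leave unreadable from compound 1 to compound 2 and it concerns another group, so it gives no size to carry over. In this assay no change beyond the scatter is therefore expected, and the expected step is a step that the limit leaves unreadable from compound 2 to compound 4 with no firm direction. For compound 4 the estimate is 4000 nM with an expected range from 1500 nM to 12000 nM and another limit would be no surprise.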

Compound 4, solubility: 15000 nM
Compound 4: middle estimate off by 3.8-fold (0.57 log units), on the low side, outside the stated range (above it).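

Among these compounds, on a saturated chain carbon bound to an aromatic carbon, pentyloxy in place of hexyl goes with an at least 3.0-fold higher number from compound 2 to compound 4 (0.47 log units; beyond the scatter) in this assay, the first step here that can be read, as the earlier one cannot. Both groups hold 6 heavy atoms, so the chain keeps its count while one carbon gives way to one oxygen. The step is only a minimum, since compound 2 stands at a limit: the limit of < 5000 nM in this assay, at which 2 of the 4 values shown sit.

On these data alone, the full size of the step stays open. So does whether the change gives a similar step with trifluoromethyl in place of nitro, and how an amine or a longer chain at this place would compare.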